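The compounds below may be only part of what the source reports. "The series", "measured", "known", "first", "only" and "open" are said of these compounds alone.

Among the three compounds measured in a functional assay on MCF7 cells (Homo sapiens) for cytotoxicity, read by MTT assay, with a stated time of 72 h, tested at 10 uM (a lower number here means less inhibition of growth, a higher number more inhibition of growth at the concentration tested), compound 3 `Cc1ccnc(/C(N)=N/NC(=S)N2CCOCC2)c1` stands lowest: in this assay compound 3 gives 6.86%, while compound 1 `Cc1cccc(/C(N)=N/NC(=S)N2CCN(c3ccccn3)CC2)n1` gives 20.8% and compound 2 `N/C(=N\NC(=S)N1CCOCC1)c1ccccn1` gives 66.7%. Among the measured compounds shown here, the one single-place step known, a number 59.8 percentage points lower from compound 2 to compound 3 (beyond the scatter), concerns the methyl group, not the ring on the thiocarbonyl carbon. Compound 4 `Cc1ccnc(/C(N)=N/NC(=S)N2CCCCC2)c1` differs from compound 3 by piperidin-1-yl in place of morpholin-4-yl on a thiocarbonyl carbon. For the measured compounds named here, no measured step bears on this exchange, so its size cannot be read from the steps, and compound 3 gives no hint of further loss. Compound 4 is therefore expected to stay near compound 3, with an expected step of a number 5.1 percentage points higher from compound 3 to compound 4 (within the scatter) within the scatter. The estimate for compound 4 is 12%, between 0% and 35%.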

Compound 4, percent growth inhibition at one concentration: 40.7%
Estimate against measurement, compound 4: 28.7 percentage points below, outside the stated range (above it).
By their numbers in this assay, from the lowest: compound 3; then compound 1; then compound 4; then compound 2.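

In this assay the group on the thiocarbonyl carbon proves to matter, with a number 33.8 percentage points higher from compound 3 to compound 4 (beyond the scatter) when piperidin-1-yl replaces morpholin-4-yl. Among the compounds shown here, the earlier step concerned only the methyl group, so this is the first sign that the ring at this position can shift growth inhibition by a large amount. Nothing available explains the size of this step. From the compounds shown here alone, whether the exchange would have a similar effect without the methyl group, as in compound 2, remains open. So does the effect of an open-chain amine such as diethylamino on this thiocarbonyl carbon.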